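Notes on an aryl swap at the assay limit

The source may report more compounds than this note shows. Statements on the series, on what has been measured and on what is new or still open speak of the compounds shown alone.

Measured in an ADME assay on Vero cells (Chlorocebus sabaeus) for cytotoxicity, read by MTT assay, with a stated time of 72 h (on this read-out lower numbers stand for stronger inhibition and higher numbers for weaker inhibition), as limits, not numbers:
- compound 1 `CN(C)C(=O)C[C@H](CSc1ccccc1)Nc1c(C(=O)N/N=C/c2ccc(F)cc2)cnc2c(C(F)(F)F)cccc12` gives > 62.5 ug/mL as a limit
- compound 2 `CN(C)C(=O)C[C@H](CSc1ccccc1)Nc1c(C(=O)N/N=C/c2ccc(OC(F)(F)F)cc2)cnc2c(C(F)(F)F)cccc12` gives > 62.5 ug/mL as a limit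
- compound 3 `CN(C)C(=O)C[C@H](CSc1ccccc1)Nc1c(C(=O)N/N=C/c2cccnc2)cnc2c(C(F)(F)F)cccc12` gives > 62.5 ug/mL as a limit

Compound 1 stands at > 62.5 ug/mL in this assay as a limit and not a number. The other measured compounds share that position (the limit of > 62.5 ug/mL in this assay, at which 3 of the 3 values shown sit).

Compound 4 `COc1ccc(/C=N/NC(=O)c2cnc3c(C(F)(F)F)cccc3c2N[C@@H](CSc2ccccc2)CC(=O)N(C)C)cc1O` carries 3-hydroxy-4-methoxyphenyl in place of 4-fluorophenyl on a carbon with a double bond to nitrogen.

Going by the values given here, three measured steps bear on this change: (a step that the two limits leave unreadable from compound 1 to compound 2), (a step that the two limits leave unreadable from compound 1 to compound 3) and (a step that the two limits leave unreadable from compound 2 to compound 3). None of them has a size that can be read, so they give no measured effect to carry over. Compounds 1, 2 and 3 all ending at the limit, with these different groups in place, points to the same outcome for compound 4, most likely another limit. No step beyond the scatter is expected in this assay on this evidence. The estimate corresponds to a step that the limit leaves unreadable from compound 1 to compound 4 as the expected step. Compound 4 is expected at 75 ug/mL with an estimated range of 35 ug/mL to 150 ug/mL in this assay when the test is read.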

Compound 4, half-maximal inhibitory concentration: > 62.5 ug/mL
Compound 4 was reported as a limit (the forecaster's own chance of this, stated with the estimate: 75%); the middle value lies beyond the limit too.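

Compound 4 ends at a limit in this assay, as do compounds 1, 2 and 3, so no step from compound 4 to these three can be read: the limit of > 62.5 ug/mL in this assay, at which 4 of the 4 values shown sit.

The compounds shown leave open where the true value of each lies beyond that limit, and whether any group in this place would give a readable value.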